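Cytotoxicity on Vero cells: hydrazone in place of ester

This account rests on a few compounds, and the source may have more. Where it says the series, first, only, none or still open, it means among the compounds named here.

Measured compounds:
Compound 1 `COC(=O)CN1CCN(c2c(F)cc3c(=O)c(C(=O)O)cn(C4CC4)c3c2OC)CC1C` in an ADME assay on Vero cells (Chlorocebus sabaeus) for cytotoxicity, read by MTT assay, with a stated time of 72 h (a higher number here means that more compound is tolerated, a lower number that less compound is tolerated), gives 500 ug/mL.
Compound 2 `COc1c(N2CCN(C/C(C)=N/O)C(C)C2)c(F)cc2c(=O)c(C(=O)O)cn(C3CC3)c12` in this assay gives 177 ug/mL.
Compound 3 `CO/N=C(\C)CCN1CCN(c2c(F)cc3c(=O)c(C(=O)O)cn(C4CC4)c3c2OC)CC1C` in this assay gives 157 ug/mL.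

Compound 1 gives the highest of the three numbers, so the most compound is tolerated in this series. Its nearest neighbour is compound 2, with a 2.8-fold lower number from compound 1 to compound 2 (0.45 log units; beyond the scatter); the furthest is compound 3, with a 3.2-fold lower number from compound 1 to compound 3 (0.50 log units; beyond the scatter). Between the two oxime-bearing compounds the gap is a 1.1-fold lower number from compound 2 to compound 3 (0.05 log units; within the scatter).

The step to compound 4 `COc1c(N2CCN(CC/C(C)=N/Nc3ccccc3)C(C)C2)c(F)cc2c(=O)c(C(=O)O)cn(C3CC3)c12` again replaces the same group on compound 1: a group of 11 heavy atoms (9 carbon, 2 nitrogen; one six-membered aromatic ring of carbon only) in place of a group of 4 heavy atoms (2 carbon, 2 oxygen; no ring), on a saturated chain carbon bound to an amine nitrogen in a ring. The two measured steps from compound 1 both exchanged the methoxycarbonyl for a chain carrying nitrogen and oxygen, and both lowered the number by a modest amount beyond the scatter. The entering group in compound 4 is considerably larger and carries a six-membered aromatic ring of carbon only and a hydrogen-bond donor, which neither measured step does. A step downward in this assay is therefore expected for compound 4, likely at least as large as those seen, expected as a 5.0-fold lower number from compound 1 to compound 4 (0.70 log units; beyond the scatter). The estimate for compound 4 is 100 ug/mL, within 40 ug/mL to 250 ug/mL.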

Compound 4, half-maximal cytotoxic concentration: 62.5 ug/mL
Beside the measured number, compound 4's estimate is 1.6-fold (0.20 log units) above it; measured number inside the range.
By their numbers in this assay, from the lowest: compound 4; then compounds 3 and 2 (each within the scatter of the next); then compound 1.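

In this assay, among these compounds, the replacements at this position had so far given two compounds, 2 and 3, that lie within the scatter of each other, and the larger group with its six-membered aromatic ring goes further, with an 8.0-fold lower number from compound 1 to compound 4 (0.90 log units; beyond the scatter). Among the compounds shown here, the same direction holds against both oxime-bearing compounds, with a 2.8-fold lower number from compound 2 to compound 4 (0.45 log units; beyond the scatter) and with a 2.5-fold lower number from compound 3 to compound 4 (0.40 log units; beyond the scatter); the last of these is the single exchange of anilino in place of methoxy on a double-bonded nitrogen, so the number depends on what sits on that nitrogen and not only on the loss of the methoxycarbonyl. Nothing available here bears on the reason for this further drop.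

Compound 4 brings in the aromatic ring and the hydrogen-bond donor together within the anilino group, so these compounds do not separate the two. Still open, on these data alone, is how a benzyloxy group on the same double-bonded nitrogen would compare, and how a carboxylic acid in place of the methoxycarbonyl would read in this assay.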